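The source may report more compounds than this note shows. Statements on the series, on what has been measured and on what is new or still open speak of the compounds shown alone.

In a functional assay on G-361 cells (Homo sapiens) for antiproliferative activity, with a stated time of 72 h (on this read-out lower numbers stand for stronger inhibition and higher numbers for weaker inhibition), the three measured compounds stand as follows.
Compound 1 `OC[C@H]1O[C@@H](n2cnc3c(NCc4cccc(Br)c4)ncnc32)[C@H](O)[C@@H]1O` gives > 166000 nM, which is a limit of the assay and not a number.
Compound 2 `COc1cccc(CNc2ncnc3c2ncn3[C@@H]2O[C@H](CO)[C@@H](O)[C@H]2O)c1O` gives 148000 nM.
Compound 3 `OC[C@H]1O[C@@H](n2cnc3c(NCc4cc(O)cc(O)c4)ncnc32)[C@H](O)[C@@H]1O` gives > 166000 nM, again a limit of the assay rather than a number.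

Compound 1 thus sits at the edge of what this assay can read, a place shared by another compound: the limit of > 166000 nM in this assay, at which 2 of the 3 values shown sit. Compound 4 `OC[C@H]1O[C@@H](n2cnc3c(NCc4cccc(C(F)(F)F)c4)ncnc32)[C@H](O)[C@@H]1O` is the next compound to be measured, and it differs from compound 1 in one spot: trifluoromethyl in place of bromo on an aromatic carbon.

Within the data shown here, no measured step makes this exact exchange. The steps that exist all swap the entire ring on the chain carbon: an at least 1.1-fold lower number from compound 1 to compound 2 (0.04 log units; that floor lies within the scatter), a step that the two limits leave unreadable from compound 1 to compound 3 and an at least 1.1-fold higher number from compound 2 to compound 3 (0.04 log units; that floor lies within the scatter). Even these larger exchanges move nothing beyond the scatter, and the limits keep most of them unreadable. The much smaller change from bromo to trifluoromethyl is therefore expected to give no step beyond the scatter in this assay, in no clear direction. Compound 4 is expected to give about 160000 nM, between 60000 nM and 400000 nM. That estimate amounts to an expected step of an at least 1.0-fold lower number from compound 1 to compound 4 (0.01 log units; that floor lies within the scatter), and a limit rather than a number remains the likelier outcome.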

Compound 4, half-maximal inhibitory concentration: > 166000 nM
Compound 4: only a limit was reported; the forecaster's own chance of this, stated with the estimate: 60%; middle value at least 1.0-fold (0.01 log units) from the limit.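

In this assay compound 4 gives > 166000 nM, which is a limit of the assay and not a number, so trifluoromethyl in place of bromo on this aromatic carbon brings no readable potency. Among these compounds, the steps from compound 1 and from compound 3 to compound 4 cannot be read, and the one step that can be read is an at least 1.1-fold higher number from compound 2 to compound 4 (0.04 log units; that floor lies within the scatter). This position has now carried two different groups with no measured number for either, and the edge of the assay has gained a third compound: the limit of > 166000 nM in this assay, at which 3 of the 4 values shown sit.

As far as these compounds go, how far apart compound 1 and compound 4 truly lie remains unknown. Also open, from the compounds shown here alone, is whether another group on this aromatic carbon, such as an amine or a carboxylic acid, would give a number rather than a limit.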